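This account rests on a few compounds, and the source may have more. Where it says the series, first, only, none or still open, it means among the compounds named here.

Compound 1, `COc1cc(-n2cnc3ccc(-c4cccc(F)c4)cc32)cc(OC)c1OC`: 2350 nM
Compound 2, `COc1cc(-c2ccc3ncn(-c4cc(OC)c(OC)c(OC)c4)c3c2)cc(OC)c1OC`: > 10000 nM
Compound 3, `COc1ccc(-c2ccc3ncn(-c4cc(OC)c(OC)c(OC)c4)c3c2)cc1`: 210 nM

In a functional assay on MCF7 cells (Homo sapiens) for antiproliferative activity, read by MTT assay, with a stated time of 72 h (a lower number here means a stronger inhibitor, a higher number a weaker inhibitor), compound 3 gives 210 nM, the lowest of the two numbers recorded. Compound 1 gives 2350 nM in this assay. Compound 2 gives > 10000 nM, which is a limit of this assay rather than a number (the limit of > 10000 nM in this assay, at which 1 of the 3 values shown sits). For the measured compounds named here, the one measured step, an 11-fold lower number from compound 1 to compound 3 (1.05 log units; beyond the scatter), concerns the aryl group on the shared core and shows that this part of the molecule can move the number a long way.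

Compound 4, `COc1cc(-n2cnc3ccc(-c4ccc(O)cc4)cc32)cc(OC)c1OC`, has not yet been measured. It differs from compound 3 in one place: hydrogen in place of methyl on an oxygen on an aromatic ring. Going by the values given here, no measured step concerns a change on the oxygen of the 4-methoxyphenyl group, so the step from compound 1 to compound 3 bears on it only in showing that the 4-position of that ring is where the large change in this assay took place. With that in mind, compound 4 is expected to give a somewhat higher number than compound 3, that is, a weaker inhibitor, with the step estimated as a 3.8-fold higher number from compound 3 to compound 4 (0.58 log units; beyond the scatter). The value of compound 4 in this assay is estimated at 800 nM, within a range of 200 nM to 4000 nM.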

Compound 4, half-maximal inhibitory concentration: 4160 nM
Compound 4: the middle estimate sits 5.2-fold (0.72 log units) below what was measured, outside the stated range (above it).
By their numbers in this assay, from the lowest: compound 3; then compounds 1 and 4 (each within the scatter of the next). At a limit, above all of these: compound 2.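

In this assay, the change from methoxy to hydroxy on the aryl group of the shared core is not a small edit: it gives a 20-fold higher number from compound 3 to compound 4 (1.30 log units; beyond the scatter), a step even larger than the one that first drew attention to this ring. The earlier compounds shown here showed only that 4-methoxyphenyl gives a much lower number than 3-fluorophenyl, and the new result ties that gain to the methyl on the oxygen, since an oxygen at the same place without its methyl does not keep it: 4-hydroxyphenyl in place of 3-fluorophenyl gives a 1.8-fold higher number from compound 1 to compound 4 (0.25 log units; within the scatter), so compound 4 and compound 1 cannot be told apart in this assay. Nothing among the measurements shown explains why removing this one methyl costs so much.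

From the compounds shown here alone, what remains open is how much of the effect depends on the size of the group on this oxygen, as an ethoxy group or a longer chain there would show. Going by these compounds, it is also open whether the oxygen itself is needed, which an amine or a plain methyl on the same ring carbon would test against compound 3.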